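The source may report more compounds than this note shows. Statements on the series, on what has been measured and on what is new or still open speak of the compounds shown alone.

Working notes on the series of amides built on the shared core of compound 1 `N#Cc1cccc(C(=O)Nc2c(C(O)(C(F)(F)F)C(F)(F)F)ccc3ccccc23)c1`. In an assay on LtK cells with ATP-sensitive inward rectifier potassium channel 11 (Homo sapiens) as the target (a higher number here means that more compound is needed for the effect, a lower number that less compound is needed), compound 1 gives 12 nM. Compound 2 `O=C(Nc1c(C(O)(C(F)(F)F)C(F)(F)F)ccc2ccccc12)c1ccc(F)cc1` gives 70 nM in this assay, and compound 3 `Cc1ccc(C(=O)Nc2c(C(O)(C(F)(F)F)C(F)(F)F)ccc3ccccc23)cc1` gives 76 nM. Compound 3 thus stands at the highest of the three numbers, though its gap to compound 2 is within the scatter, a 1.1-fold higher number from compound 2 to compound 3 (0.04 log units; within the scatter); the gap to compound 1 is real, a 6.3-fold higher number from compound 1 to compound 3 (0.80 log units; beyond the scatter), and compound 2 shows the same kind of separation from compound 1, a 5.8-fold higher number from compound 1 to compound 2 (0.77 log units; beyond the scatter).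

The next compound is compound 4 `O=C(Nc1c(C(O)(C(F)(F)F)C(F)(F)F)ccc2ccccc12)c1cccnc1`. The change from compound 3 is pyridin-3-yl in place of 4-methylphenyl on a carbonyl carbon. Among the compounds with values here, no measured step exchanges the aryl of compound 3 for a heteroaryl, so the bearing on it is indirect. The step from compound 1 to compound 3 shows that the group on the carbonyl carbon can move the number by a modest amount, while the step from compound 2 to compound 3 shows two such groups that do not differ. Compound 4 is therefore expected to give 40 nM in this assay, within 12 nM to 130 nM, a step of a 1.9-fold lower number from compound 3 to compound 4 (0.28 log units; within the scatter) expected toward a lower number but not firmly beyond the scatter.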

Compound 4, half-maximal effective concentration: 60 nM
Beside the measured number, compound 4's estimate is 1.5-fold (0.18 log units) below it, and the stated range covers the measured number.
By their numbers in this assay, from the lowest: compound 1; then compounds 4, 2 and 3 (each within the scatter of the next).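

A heteroaryl on the carbonyl carbon now stands level with the two substituted phenyls: in this assay, pyridin-3-yl gives a 1.3-fold lower number from compound 3 to compound 4 (0.10 log units; within the scatter) and a 1.2-fold lower number from compound 2 to compound 4 (0.07 log units; within the scatter), so exchanging either phenyl for this ring, with its one hydrogen-bond acceptor, does not move the number beyond the scatter. Among the four groups on the carbonyl carbon, only 3-cyanophenyl stands apart, with a 5.0-fold higher number from compound 1 to compound 4 (0.70 log units; beyond the scatter), and this separation now holds against a ring with a hetero atom as well as against the two substituted phenyls. No measured evidence bears on why these groups behave in this way.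

On these data alone, whether the nitrile itself sets compound 1 apart stays open. Also open, as far as these compounds go, is how the number responds on the same carbonyl carbon to a phenyl carrying an amine or a carboxylic acid, or to a saturated ring such as cyclohexyl.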